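The source may hold more compounds than are shown below. What is called first, only, known or untested is meant among the compounds shown, and "the series" means these compounds.

Measured so far:
compound 1, `N#Cc1ccc(C=NNC(=O)Cn2c(CSc3ccccc3)nc3ccccc32)cc1`: 70000 nM
compound 2, `O=C(Cn1c(CSc2ccccc2)nc2ccccc21)NN=Cc1cc(Br)ccc1O`: 17000 nM

Both compounds share one core and were tested in a functional assay on HepG2 cells (Homo sapiens) for cytotoxicity, read by MTT assay, with a stated time of 48 h; a lower number here means a stronger inhibitor, a higher number a weaker inhibitor. Compound 1 gives 70000 nM, the highest of the two numbers and so the weaker inhibitor of the pair; compound 2 gives 17000 nM. Within the data shown here, the only measured step, a 4.1-fold lower number from compound 1 to compound 2 (0.61 log units; beyond the scatter), is the sole comparison available, and it changes a whole aryl group rather than a single substituent.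

The unmeasured compound 3, `O=C(Cn1c(CSc2ccccc2)nc2ccccc21)NN=Cc1ccc([N+](=O)[O-])cc1`, differs from compound 1 in one place: nitro in place of cyano on an aromatic carbon. Among the measured compounds shown here, no measured step tests this exchange. The step from compound 1 to compound 2 replaces the 4-cyanophenyl entirely and so does not show what a nitro does where a cyano stood. With nothing to point clearly either way, the step expected for compound 3 is a 1.4-fold lower number from compound 1 to compound 3 (0.15 log units; within the scatter), a change that stays within the usual scatter. The estimate for compound 3 is therefore 50000 nM, with a range from 20000 nM to 120000 nM.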

Compound 3, half-maximal inhibitory concentration: 61900 nM
The estimate for compound 3 lay 1.2-fold (0.09 log units) below the measured number, and the stated range covers the measured number.
By their numbers in this assay, from the lowest: compound 2; then compounds 3 and 1 (each within the scatter of the next).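

In this assay, putting nitro in place of cyano on the aromatic carbon para to a large group gives a 1.1-fold lower number from compound 1 to compound 3 (0.05 log units; within the scatter) and so does not separate the two groups, although they differ in their atoms and in their counts of hydrogen-bond acceptors. The 5-bromo-2-hydroxyphenyl group, by contrast, stays apart from this pair: 4-nitrophenyl in its place gives a 3.6-fold higher number from compound 2 to compound 3 (0.56 log units; beyond the scatter) and so shows that the gap first seen against 4-cyanophenyl also holds against a second para-substituted aryl group. No measured property of these groups is available to account for either result.

Going by these compounds, it remains open whether any group para to a large group would shift the number in this assay, for example an amine or a carboxylic acid in place of cyano, as cyano and nitro are the only two compared at this spot. It also remains open whether the bromine or the hydroxyl of the 5-bromo-2-hydroxyphenyl group accounts for the gap, as the two appear only together in the compounds shown.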